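The source may hold more compounds than are shown below. What is called first, only, known or untested is meant among the compounds shown, and "the series" means these compounds.

Three stereoisomers of one small ring have been tested in an assay for inhibition of alpha-N-acetylgalactosaminidase (Gallus gallus), tested at 1000 uM; a lower number here means less inhibition, a higher number more inhibition at the concentration tested (going by the name of the read-out). Compound 1 `O=C(O)[C@H]1NC[C@H](O)[C@@H](O)[C@H]1O` gives 31%. Compound 2 `O=C(O)[C@H]1NC[C@@H](O)[C@H](O)[C@@H]1O` gives 11%, and compound 3 `O=C(O)[C@@H]1NC[C@H](O)[C@@H](O)[C@H]1O` gives 4%. Compound 3 therefore stands lowest of the three numbers shown, though its gap to compound 2 is within the scatter, while its gap to compound 1 is beyond it.

The measured steps are all changes of configuration alone. There is a number 20 percentage points lower from compound 1 to compound 2 (beyond the scatter), which rests on (the fact that compounds 1 and 2 differ only in the configuration as drawn); there is a number 27 percentage points lower from compound 1 to compound 3 (beyond the scatter), which rests on (the fact that compounds 1 and 3 differ only in the configuration as drawn); and there is a number 7 percentage points lower from compound 2 to compound 3 (within the scatter), which rests on (the fact that compounds 2 and 3 differ only in the configuration as drawn). Turning a single centre or three centres each moved the number by a modest amount, while the full mirror image of compound 2 gave a step within the scatter.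

Compound 4 `O=C(O)[C@H]1NC[C@H](O)[C@@H](O)[C@@H]1O` is the next isomer. Its change from compound 3 is the two compounds have the same atoms and bonds and differ only in configuration as drawn: 2 of 4 stereo elements differ; a stereocentre at a saturated ring carbon is drawn R in compound 3 and S in compound 4; a stereocentre at a saturated ring carbon is drawn S in compound 3 and R in compound 4. Given the sizes of the steps just described, a modest shift in this assay is expected, and because compound 3 sits at 4% the room is mainly upward. The expected step is a number 11 percentage points higher from compound 3 to compound 4 (beyond the scatter). For compound 4 the estimate is 15%, with a likely range from 2% to 40%.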

Compound 4, a percentage reported as inhibition, at one concentration (the size of the read-out at that concentration, not a potency): 0.2%
Beside the measured number, compound 4's estimate is 14.8 percentage points above it; the whole stated range lies above it.
By their numbers in this assay, from the lowest: compounds 4, 3 and 2 (each within the scatter of the next, the first and the last beyond it); then compound 1.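

Going by these compounds alone, a single inverted stereocentre is enough for a number 30.8 percentage points lower from compound 1 to compound 4 (beyond the scatter) in this assay, and this is a different centre from the one that separates compound 3 from compound 1, so two separate single inversions of compound 1 now each lower the number beyond the scatter: the fact that compounds 1 and 4 differ only in the configuration as drawn. The low end of the series is not one clean group, since a number 10.8 percentage points lower from compound 2 to compound 4 (beyond the scatter) is beyond the scatter even though compound 3 lies within the scatter of both of these isomers: the fact that compounds 2 and 4 differ only in the configuration as drawn. Changing two centres gives no readable difference in a number 3.8 percentage points lower from compound 3 to compound 4 (within the scatter) and shows that not every change of configuration registers once the number is already this low: the fact that compounds 3 and 4 differ only in the configuration as drawn.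

The compounds shown leave open how the remaining stereoisomers of the shared core behave, and whether any single centre of compound 1 can be inverted with the inhibition kept. They also leave open whether a methyl ester or a hydroxymethyl group in place of the carboxylic acid, or a longer chain on the ring nitrogen, would keep or raise the inhibition seen with compound 1.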